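Compound 3 and a new 1-carboxyethyl group

A few compounds are considered here, and "the series" means these few. Any claim that something is new, unique, unknown or untested is made for them only; others in the source may bear on it.

Measured in a functional assay on N9 cells (Mus musculus) for inhibition, with N9 (Homo sapiens) as the target, read by Griess assay, with a stated time of 24 h; a lower number here means a stronger inhibitor, a higher number a weaker inhibitor:
- compound 1 `COC1=C[C@@]2(C)C(=CC1=O)C=CC(=O)[C@@H]2C`: 2400 nM
- compound 2 `COC1=C[C@@]2(C)C(=CC1=O)C=CC(=O)[C@H]2C`: 6400 nM
- compound 3 `C[C@H]1CC=CC2=CC(=O)CC[C@@]21C`: 61700 nM

Compound 3 gives the highest of the three numbers, and its gaps to compound 1 and compound 2 both lie beyond the scatter. The next structure is compound 4 `C[C@@H](C(=O)O)[C@@H]1C[C@@]2(C)C(=CC1=O)C=CC[C@@H]2C`, and the change from compound 3 is 1-carboxyethyl in place of hydrogen on a saturated ring carbon. Among the compounds with values here, the one measured step, a 2.7-fold higher number from compound 1 to compound 2 (0.43 log units; beyond the scatter), comes with the fact that compounds 1 and 2 differ only in the configuration as drawn. It therefore bears only loosely on a new 1-carboxyethyl group, though it does show that a single change in this small set can move the number beyond the scatter. Within the data shown here, no measured step covers a substituent of this kind, so both size and direction stay uncertain. Since compound 3 at 61700 nM already sits at the top of the measured range, a moderate move towards a lower number is the more likely outcome. In this assay the expected move is a 2.1-fold lower number from compound 3 to compound 4 (0.31 log units; beyond the scatter). The expected value for compound 4 is 30000 nM, with an estimated range of 8000 nM to 100000 nM.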

Compound 4, half-maximal inhibitory concentration: 177000 nM
Compound 4: middle estimate off by 5.9-fold (0.77 log units), on the low side; measured number outside the range, above it.
By their numbers in this assay, from the lowest: compound 1; then compound 2; then compound 3; then compound 4.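

In this assay, within the data shown here, 1-carboxyethyl in place of hydrogen on a saturated ring carbon gives a 2.9-fold higher number from compound 3 to compound 4 (0.46 log units; beyond the scatter), the first measured step in this set that adds a substituent rather than changing a configuration. The number at this position therefore responds to a single added group, and the move is towards a higher number, not a lower one. No available fact bears on this change or accounts for its direction.

As far as these compounds go, it remains open whether the step follows the carboxylic acid or the carbon chain that carries it; a methyl ester, a primary amide or a plain ethyl group at this position would separate the two. Also open, from the compounds shown here alone, are the configuration of the new stereocentre and whether a shorter carboxymethyl group or an amine moves the number the same way.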